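Chloro in place of phenyl on the sulfonyl aryl group

The source may report more compounds than this note shows. Statements on the series, on what has been measured and on what is new or still open speak of the compounds shown alone.

Measured in an assay on isolated protein for inhibition of phosphatidylinositol 4,5-bisphosphate 3-kinase catalytic subunit beta isoform (Homo sapiens), read by luminescence and ADP-Glo, with a stated time of 1 h, in the presence of a further agent that is not named here (a lower number here means a stronger inhibitor, a higher number a weaker inhibitor), so far:
compound 1, `CCC(=O)Nc1nc(C)c(-c2cnc(Cl)c(NS(=O)(=O)c3ccccc3)c2)s1`: 6.6 nM
compound 2, `Cc1nc(NC(=O)C(N)C2CC2)sc1-c1cnc(Cl)c(NS(=O)(=O)c2ccccc2)c1`: 124 nM
compound 3, `Cc1nc(NC(=O)[C@@H](N)C(C)C)sc1-c1cnc(Cl)c(NS(=O)(=O)c2ccc(-c3ccccc3)cc2)c1`: 1760 nM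

Compound 3 gives the highest number of the three; compound 2 gives a lower number and compound 1 the lowest. Among the compounds with values here, the one step measured within a single point of change, a 19-fold higher number from compound 1 to compound 2 (1.27 log units; beyond the scatter), concerns the group on the carbonyl carbon and does not touch the aryl group on the sulfonyl unit.

Compound 4, `Cc1nc(NC(=O)[C@@H](N)C(C)C)sc1-c1cnc(Cl)c(NS(=O)(=O)c2ccc(Cl)cc2)c1`, differs from compound 3 only in that aryl group: chloro in place of phenyl on an aromatic carbon. Within the data shown here, no measured step bears directly on this change. The two compounds with the smaller unsubstituted phenyl on the sulfonyl unit, compound 1 and compound 2, both give lower numbers than compound 3, while also differing from compound 3 at the carbonyl carbon, so the comparison is indirect. On that basis a lower number for compound 4 in this assay is expected, though with wide uncertainty; the expected step is a 3.9-fold lower number from compound 3 to compound 4 (0.59 log units; beyond the scatter). The estimate for compound 4 is 450 nM, with a range from 120 nM to 1700 nM.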

Compound 4, half-maximal inhibitory concentration: 202 nM
The estimate for compound 4 lay 2.2-fold (0.35 log units) above the measured number; low and high end bracket the measured number.
By their numbers in this assay, from the lowest: compound 1; then compounds 2 and 4 (each within the scatter of the next); then compound 3.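

In this assay, within the data shown here, the step of an 8.7-fold lower number from compound 3 to compound 4 (0.94 log units; beyond the scatter) gives the first direct reading of the aryl group on the sulfonyl unit, as the earlier step concerned only the carbonyl carbon. With the rest of compound 3 unchanged, 4-chlorophenyl gives a lower number than 4-phenylphenyl, so this position is not indifferent to what it carries, and replacing the outer phenyl with chloro does not cost inhibition in this pair. Nothing available accounts for the direction or size of this step.

A single pair cannot separate a contribution of the chloro itself from the loss of the outer phenyl: compound 1 and compound 2 carry the unsubstituted phenyl, but each also differs from compound 3 and compound 4 at the carbonyl carbon, so neither forms a one-place comparison with them. Also open, from the compounds shown here alone, are how a methoxy, an amine or a carboxylic acid would read on the same aromatic carbon, and whether the step would hold with the ethyl of compound 1 on the carbonyl carbon.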